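An Acid Becomes Its Methyl Ester

A few compounds are considered here, and "the series" means these few. Any claim that something is new, unique, unknown or untested is made for them only; others in the source may bear on it.

Of the compounds shown here, two have been tested in an assay on a protein complex for inhibition of CDK8/Cyclin C (Homo sapiens), with a stated time of 1 h, tested at 10 uM; on this read-out lower numbers stand for less inhibition and higher numbers for more inhibition at the one concentration tested (going by the name of the read-out). Compound 1 `O=C(O)COc1ccncc1-c1ccc2ccccc2c1` gives 16% in this assay. Compound 2 `Cn1ncc2cc(-c3cnccc3/C=C/C(=O)O)ccc21` gives 102% in this assay. Within the data shown here, compound 1 thus stands lowest of the two numbers, and compound 2, its only neighbour, lies above it by a gap well beyond the scatter. The two compounds share no single-point change, so only their two values themselves can be compared.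

Compound 3 `COC(=O)COc1ccncc1-c1ccc2ccccc2c1` has not yet been measured. It differs from compound 1 by methyl in place of hydrogen on an oxygen next to a carbonyl group; hydroxy becomes methoxy and carboxy becomes methoxycarbonyl. Among the measured compounds shown here, no measured pair shows what this change does in this assay. Compound 1 already sits near the bottom of the scale, leaving little room downward. The step expected a number 6 percentage points lower from compound 1 to compound 3 (within the scatter) is therefore small, within the scatter or slightly downward. For compound 3 the estimate in this assay is 10%, with a range from -5% to 40%.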

Compound 3, a percentage reported as inhibition, at one concentration (the size of the read-out at that concentration, not a potency): 11%
For compound 3 the middle estimate is 1 percentage points below the measured one; the range from low to high includes it.
By their numbers in this assay, from the lowest: compounds 3 and 1 (each within the scatter of the next); then compound 2.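

In this assay, among these compounds, methyl in place of hydrogen on an oxygen next to a carbonyl group gives a number 5 percentage points lower from compound 1 to compound 3 (within the scatter), the first measured reading of this change. On this core, then, the carboxy and methoxycarbonyl forms of the side chain cannot be told apart, and both stay near the bottom of the scale, where a further fall would have little room to show. No supporting measurement is available to explain this result.

Going by these compounds, whether the same change would also leave the number within the scatter on a compound that starts high, such as the acid compound 2, remains open. Also open, on these data alone, is whether a primary amide, an amine or a longer chain in place of the carboxymethyl group would lift the core of compound 1 from the bottom of the scale.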